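Aryl exchange on the oxolan-3-yl compound

The compounds below may be only part of what the source reports. "The series", "measured", "known", "first", "only" and "open" are said of these compounds alone.

In a functional assay on PC-3 cells (Homo sapiens) for cytotoxicity, read by MTT assay, with a stated time of 72 h (on this read-out lower numbers stand for stronger inhibition and higher numbers for weaker inhibition), compound 1 (`COc1cc2ncnc(Nc3ccc(F)c(Cl)c3)c2cc1NC(=O)/C=C/c1ccc(F)cc1Cl`) gives 32700 nM and compound 3 (`COc1ccc(/C=C/C(=O)Nc2cc3c(Nc4ccc(F)c(Cl)c4)ncnc3cc2OC)c(OC)c1`) gives 38500 nM while compound 2 (`COc1ccc(/C=C/C(=O)Nc2cc3c(Nc4ccc(F)c(Cl)c4)ncnc3cc2O[C@H]2CCOC2)c(OC)c1`) gives 2760 nM as the lowest of the three numbers, beyond the scatter from both others. Compound 4 (`O=C(/C=C/c1cc(Br)c(O)c(Br)c1)Nc1cc2c(Nc3ccc(F)c(Cl)c3)ncnc2cc1O[C@H]1CCOC1`) carries 3,5-dibromo-4-hydroxyphenyl in place of 2,4-dimethoxyphenyl (3,5-dibromo-4-hydroxyphenyl in place of 2,4-dimethoxyphenyl on a double-bonded chain carbon bound to a double-bonded chain carbon). The large step (a 14-fold higher number from compound 2 to compound 3 (1.14 log units; beyond the scatter)) concerns the oxolan-3-yl group, which compound 4 keeps, so it offers no guide here. Among the compounds with values here, the only measured aryl exchange (a 1.2-fold higher number from compound 1 to compound 3 (0.07 log units; within the scatter)) lies within the scatter, though it involves neither compound 4 nor its new group. No clear direction is therefore expected for the estimated change (a 1.1-fold higher number from compound 2 to compound 4 (0.04 log units; within the scatter)) in this assay and no step beyond the scatter is predicted. For compound 4 the estimate is 3000 nM (expected range 800 nM to 11000 nM).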

Compound 4, half-maximal inhibitory concentration: 25500 nM
The estimate for compound 4 lay 8.5-fold (0.93 log units) below the measured number, and the stated range ends below it.
By their numbers in this assay, from the lowest: compound 2; then compounds 4, 1 and 3 (each within the scatter of the next).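

In this assay the aryl group on the double-bonded chain carbon matters on the oxolan-3-yl compounds, with 3,5-dibromo-4-hydroxyphenyl in place of 2,4-dimethoxyphenyl giving a 9.2-fold higher number from compound 2 to compound 4 (0.97 log units; beyond the scatter) on this scaffold. The earlier aryl exchange, a 1.2-fold higher number from compound 1 to compound 3 (0.07 log units; within the scatter) in the methyl-on-oxygen pair, did not show this sensitivity. No supporting data bear on the cause of the new step. The compounds shown leave open whether the bromine atoms or the hydroxyl carry the step. A 4-hydroxyphenyl or a 3,5-dibromophenyl group on the oxolan-3-yl compound would separate the two.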